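The source may report more compounds than this note shows. Statements on the series, on what has been measured and on what is new or still open speak of the compounds shown alone.

Measured in an assay on cells with melanin-concentrating hormone receptor 1 (Homo sapiens) as the target, read by radioligand binding; on this read-out lower numbers stand for stronger inhibition and higher numbers for weaker inhibition:
compound 1 `Nc1ccc2cccc(OC3CCCCC3)c2n1` gives 361 nM.
compound 2 `Nc1ccc2cccc(OC3CCCC3)c2n1` reaches only a limit of this assay, > 2000 nM.

Compound 1 holds the only number shown in this assay; the other value is a limit (the limit of > 2000 nM in this assay, at which 1 of the 2 values shown sits). Among the compounds with values here, the one measured step, an at least 5.5-fold higher number from compound 1 to compound 2 (0.74 log units; beyond the scatter), concerns the ring on the ether oxygen: cyclopentyl in place of cyclohexyl. Compound 3 `CC1CCCCC1Oc1cccc2ccc(N)nc12` keeps the cyclohexyl and differs from compound 1 by methyl in place of hydrogen on a saturated ring carbon. That step bears only loosely on the ring-size step, so for compound 3 an expected shift of a 1.1-fold higher number from compound 1 to compound 3 (0.04 log units; within the scatter) in this assay, within the scatter, is taken. Compound 3 is estimated at 400 nM, between 150 nM and 1200 nM.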

Compound 3, half-maximal inhibitory concentration: 32 nM
Compound 3: the middle estimate sits 13-fold (1.10 log units) above what was measured, outside the stated range (below it).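

In this assay, the saturated ring carbon next to the ring atom that bears a large group accepts a substituent, and methyl in place of hydrogen there gives an 11-fold lower number from compound 1 to compound 3 (1.05 log units; beyond the scatter). The earlier pair varied only ring size; this is the first change shown that lowers the number, making the cyclohexyl ring itself a productive place to substitute. No measured property shown accounts for this gain. Open, as far as these compounds go, is whether ethyl or hydroxyl on the same ring carbon acts like methyl. Also open, from the compounds shown here alone, is whether methyl on other carbons of the ring gives a similar step.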